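Estimating compound 4 from three measured analogues

A few compounds are considered here, and "the series" means these few. Any claim that something is new, unique, unknown or untested is made for them only; others in the source may bear on it.

Compound 1 `O=C(NC[C@@H]1C[C@@H]2C=C[C@@H]1C2)NS(=O)(=O)N1CCC(CCNC(=O)c2cc(Cl)ccn2)CC1` gives 16% in a functional assay on the whole organism (blood) with Rattus norvegicus as the target, with stated times of 24 h and 1 h, at a dose of 1 mg/kg by the intraperitoneal route; on this read-out lower numbers stand for a weaker effect and higher numbers for a stronger effect at the one dose given; compound 2 `Cn1cccc(C(=O)NCCC2CCN(S(=O)(=O)NC(=O)NC[C@@H]3C[C@@H]4C=C[C@@H]3C4)CC2)c1=O` gives 19%; compound 3 `O=C(NC1CCCCC1)NS(=O)(=O)N1CCC(CCNC(=O)c2cccc3cccnc23)CC1` gives 29%.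

On these numbers compound 2 stands second highest of the three; its nearest neighbour is compound 1 and its furthest is compound 3, and both gaps are within the scatter. The unmeasured compound 4 `O=C(NC[C@@H]1C[C@@H]2C=C[C@@H]1C2)NS(=O)(=O)N1CCC(CCNC(=O)c2cc(Cl)cc3cccnc23)CC1` differs from compound 2 in one place: a group of 11 heavy atoms (9 carbon, 1 nitrogen, 1 chlorine; one six-membered aromatic ring of carbon only, one six-membered aromatic ring with 1 hetero atom) in place of a group of 8 heavy atoms (6 carbon, 1 nitrogen, 1 oxygen; one six-membered aromatic ring with 1 hetero atom), on a carbonyl carbon. Going by the values given here, the one measured step at that carbonyl carbon, a number 3 percentage points higher from compound 1 to compound 2 (within the scatter), stayed within the scatter. Compound 3, whose group on that carbonyl carbon also holds one six-membered aromatic ring of carbon only and one with 1 hetero atom, has a different urea end, and its value lies within the scatter of compound 2. No step beyond the scatter is therefore expected in this assay. Compound 4 is estimated at 25% (range 12% to 40%), which is expected to mean a step of a number 6 percentage points higher from compound 2 to compound 4 (within the scatter).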

Compound 4, a percentage reported as activity, at one dose (the size of the read-out at that dose, not a potency): 16%
For compound 4 the middle estimate is 9 percentage points above the measured one; measured number inside the range.
By their numbers in this assay, from the lowest: compounds 1, 4, 2 and 3 (each within the scatter of the next, the first and the last beyond it).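

In this assay, going by these compounds alone, 6-chloroquinolin-8-yl in place of 4-chloropyridin-2-yl on the carbonyl carbon gives no change at the digits printed from compound 1 to compound 4 (within the scatter), and the same group in place of the one in compound 2 gives a number 3 percentage points lower from compound 2 to compound 4 (within the scatter). With the urea end held constant, all three groups at this carbonyl carbon, including one that holds a second aromatic ring, thus stay within the scatter of one another. Nothing available here bears on the reason for this result.

As far as these compounds go, whether an amine or a carboxylic acid on the aromatic group would move the read-out stays open. The compounds shown also do not separate the effect of the urea end from that of the other difference in compound 3.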